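The source may hold more compounds than are shown below. What is called first, only, known or untested is meant among the compounds shown, and "the series" means these compounds.

Measured to date in a functional assay on HeLa cells (Homo sapiens) for cytotoxicity, read by MTT assay, with a stated time of 72 h; on this read-out lower numbers stand for stronger inhibition and higher numbers for weaker inhibition:

compound 1, `COc1cccc(/C=C/C(=O)Nc2cc(OC)c(OC)c(OC)c2)c1`: 12300 nM
compound 2, `COc1ccc(/C=C/C(=O)Nc2cc(C(=O)c3cc(OC)c(OC)c(OC)c3)ccc2OC)cc1`: 10700 nM
compound 3, `COc1ccc(C(=O)c2cc(OC)c(OC)c(OC)c2)cc1NC(=O)/C=C/c1ccc(F)cc1`: 60 nM

Compound 3 gives the lowest number of the three; its nearest neighbour is compound 2 and the furthest is compound 1, both beyond the scatter. Going by the values given here, the single one-place step in the set, a 180-fold lower number from compound 2 to compound 3 (2.25 log units; beyond the scatter), shows that the group on the aromatic carbon of the cinnamoyl ring is not indifferent.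

Compound 4, `COc1ccc(C(=O)c2cc(OC)c(OC)c(OC)c2)cc1NC(=O)/C=C/c1ccc(N)cc1`, is the next entry for this assay. The change from compound 3 is amino in place of fluoro on an aromatic carbon. Among the compounds with values here, no measured pair shows amino against fluoro at this place, so the only bearing evidence is the large step between compound 2 and compound 3, which marks the site as sensitive without saying which way amino will go. On that footing a loss is expected for compound 4, estimated as a 4.2-fold higher number from compound 3 to compound 4 (0.62 log units; beyond the scatter), leaving it well inside the range of compound 3 and compound 2 rather than matching either. The estimate for compound 4 is 250 nM, within 40 nM to 1500 nM.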

Compound 4, half-maximal inhibitory concentration: 14700 nM
Estimate against measurement, compound 4: 59-fold (1.77 log units) below, and the stated range ends below it.
By their numbers in this assay, from the lowest: compound 3; then compounds 2, 1 and 4 (each within the scatter of the next).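

In this assay, the low number of compound 3 does not survive the change from 4-fluorophenyl to 4-aminophenyl: the step is a 250-fold higher number from compound 3 to compound 4 (2.39 log units; beyond the scatter) and is beyond the scatter. Amino and methoxy on this aromatic carbon cannot be told apart, with a 1.4-fold higher number from compound 2 to compound 4 (0.14 log units; within the scatter) lying within the scatter, so among the three groups shown here, only fluoro goes with a low number. The data at hand offer no measurement that accounts for this difference.

Going by these compounds, whether the low number is particular to fluoro or is shared by other groups on this carbon, such as chloro, trifluoromethyl or nitrile, stays open. Also open, on these data alone, is how the plain phenyl ring, with only hydrogen at this place, compares with compound 3.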